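Swapping methoxy for chloro on a weaker indole regioisomer

A few compounds are considered here, and "the series" means these few. Any claim that something is new, unique, unknown or untested is made for them only; others in the source may bear on it.

Compound 1 `COc1ccc(S(=O)(=O)c2cc3cnc(Nc4ccc5[nH]ccc5c4)nc3n(C)c2=O)cc1` gives 300 nM in a functional assay on K562 cells (Homo sapiens) for inhibition, read by trypan blue exclusion, with a stated time of 72 h; a lower number here means a stronger inhibitor, a higher number a weaker inhibitor. Compound 2 `Cn1c(=O)c(S(=O)(=O)c2ccc(Cl)cc2)cc2cnc(Nc3ccc4[nH]ccc4c3)nc21` differs from it by chloro in place of methoxy on an aromatic carbon and gives 100 nM; this change made a 3.0-fold lower number from compound 1 to compound 2 (0.48 log units; beyond the scatter). Compound 3 `COc1ccc(S(=O)(=O)c2cc3cnc(Nc4cccc5[nH]ccc45)nc3n(C)c2=O)cc1` has a different core, the difference being (1H-indol-4-yl in place of 1H-indol-5-yl on a nitrogen on an aromatic ring), and gives 5000 nM, so that step was a 17-fold higher number from compound 1 to compound 3 (1.22 log units; beyond the scatter).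

Compound 4 `Cn1c(=O)c(S(=O)(=O)c2ccc(Cl)cc2)cc2cnc(Nc3cccc4[nH]ccc34)nc21` has not yet been measured in this assay. It differs from compound 3 by chloro in place of methoxy on an aromatic carbon, the same change seen from compound 1 to compound 2, at the same place. Compound 4 is therefore expected to show a 2.9-fold lower number from compound 3 to compound 4 (0.47 log units; beyond the scatter), resting on the size of the step that the same change made in a 3.0-fold lower number from compound 1 to compound 2 (0.48 log units; beyond the scatter). The estimate for compound 4 is 1700 nM, with a range from 700 nM to 4000 nM.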

Compound 4, half-maximal inhibitory concentration: 5000 nM
The estimate for compound 4 lay 2.9-fold (0.47 log units) below the measured number; measured number outside the range, above it.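

In this assay, chloro in place of methoxy gave no change at the digits printed from compound 3 to compound 4 (within the scatter), so the stronger result seen on the core of compound 1 did not carry over to the core of compound 3: the same change on two cores in this assay, a 3.0-fold lower number (0.48 log units; beyond the scatter) from compound 1 to compound 2 and no change at the digits printed (within the scatter) from compound 3 to compound 4, 3.0-fold (0.48 log units) apart, beyond the scatter of two such steps

Seen the other way, moving from 1H-indol-5-yl to 1H-indol-4-yl gave a 50-fold higher number from compound 2 to compound 4 (1.70 log units; beyond the scatter), a larger step than the one with methoxy in place: the same change on two cores in this assay, a 17-fold higher number (1.22 log units; beyond the scatter) from compound 1 to compound 3 and a 50-fold higher number (1.70 log units; beyond the scatter) from compound 2 to compound 4, 3.0-fold (0.48 log units) apart, beyond the scatter of two such steps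

So in this series the size of the chloro step cannot simply be transferred between these two cores, although two pairs do not show why the steps differ or how other cores would behave.

As far as these compounds go, it remains open how other groups at the same place, such as an amine or a carboxylic acid, would behave on each core.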